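The compounds below may be only part of what the source reports. "The series", "measured", "known", "first", "only" and "open" are said of these compounds alone.

Measured so far:
- Compound 1, `COC(=O)C[C@H](NC(=O)OC(C)(C)C)C(=O)N(Cc1ccc(F)cc1)C1(C(=O)NC(C)(C)C)CCN(Cc2ccccc2)CC1`: 80000 nM
- Compound 2, `CCC(C)N(C(=O)[C@H](CC(=O)OC)NC(=O)OC(C)(C)C)C1(C(=O)NCc2ccccc2)CCN(Cc2ccccc2)CC1`: 84000 nM

In an ADME assay on MDCK cells (Canis lupus familiaris) for cytotoxicity, read by microscopy, with a stated time of 72 h (a lower number here means that less compound is tolerated, a higher number that more compound is tolerated), compound 1 gives 80000 nM, and compound 2 gives 84000 nM. Compound 2 holds the higher of the two numbers, but the gap to compound 1 lies within the scatter, so the two compounds cannot be told apart here. Compound 3, `COC(=O)C[C@H](NC(=O)OC(C)(C)C)C(=O)N(Cc1ccc(Cl)cc1)C1(C(=O)NCc2ccccc2)CCN(Cc2ccccc2)CC1`, differs from compound 2 by one change: 4-chlorobenzyl in place of sec-butyl on an amide-type nitrogen. Within the data shown here, no measured pair shows what such a change does. Since compound 1 and compound 2 sit so close together, the expected step is a 1.1-fold lower number from compound 2 to compound 3 (0.02 log units; within the scatter), which stays within the scatter. Compound 3 is therefore estimated to give 80000 nM, with a range from 40000 nM to 160000 nM.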

Compound 3, minimum cytotoxic concentration: 100000 nM
The estimate for compound 3 lay 1.3-fold (0.10 log units) below the measured number; measured number inside the range.
By their numbers in this assay, from the lowest: compounds 1, 2 and 3 (each within the scatter of the next).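

In this assay, placing 4-chlorobenzyl in place of sec-butyl on the amide-type nitrogen gives a 1.2-fold higher number from compound 2 to compound 3 (0.08 log units; within the scatter). This single-place comparison therefore shows that a larger group with a six-membered aromatic ring and a chlorine can stand at this nitrogen without separating compound 3 from compound 2 in this read-out. No further measurement here offers an explanation for this result. Still open, from the compounds shown here alone, is whether an amine, a carboxylic acid or a longer chain on this nitrogen would give a number beyond the scatter.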